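A few compounds are considered here, and "the series" means these few. Any claim that something is new, unique, unknown or untested is made for them only; others in the source may bear on it.

Among the measured compounds shown here, only three compounds have been tested so far in a functional assay on MCF7 cells (Homo sapiens) for antiproliferative activity, read by sulforhodamine B assay, with a stated time of 48 h; on this read-out higher numbers stand for weaker inhibition and lower numbers for stronger inhibition. Compound 1 `COc1cccc(/C=C/C(=O)/C=C(O)/C=C/c2cccc(OC)c2OC)c1OC` gives > 50000 nM, which is a limit of the assay and not a number. Compound 2 `COc1ccc(OC)c(/C=C/C(=O)/C=C(O)/C=C/c2cc(OC)ccc2OC)c1` gives > 50000 nM, which is also a limit. For the measured compounds named here, compound 3 `COc1cccc(/C=C/C(=O)C(=Cc2cc(OC)c(OC)c(OC)c2)C(=O)/C=C/c2cccc(OC)c2OC)c1OC` gives 840 nM, the only true number in the set, so it is the natural reference point.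

The next compound to be tested, compound 4 `COc1cc(C=C(C(=O)/C=C/c2cccc(OC)c2OC)C(=O)/C=C/c2cccc(OC)c2OC)cc(Br)c1O`, differs from compound 3 in one place: a 3-bromo-4-hydroxy-5-methoxyphenyl stands in place of the 3,4,5-trimethoxyphenyl on a double-bonded chain carbon bound to a double-bonded chain carbon, (3-bromo-4-hydroxy-5-methoxyphenyl in place of 3,4,5-trimethoxyphenyl on a double-bonded chain carbon bound to a double-bonded chain carbon). Going by the values given here, no measured pair shows what this swap does, so any forecast is uncertain. The best guess is a step no larger than the usual scatter, with no firm direction, and the forecast rests on compound 3 at 840 nM. The expected change is a 1.1-fold lower number from compound 3 to compound 4 (0.05 log units; within the scatter). The estimated value for compound 4 is 750 nM, with an expected range of 200 nM to 2800 nM.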

Compound 4, half-maximal inhibitory concentration: 360 nM
Estimate against measurement, compound 4: 2.1-fold (0.32 log units) above; the range from low to high includes it.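

In this assay, 3-bromo-4-hydroxy-5-methoxyphenyl in place of 3,4,5-trimethoxyphenyl on a double-bonded chain carbon bound to a double-bonded chain carbon gives a 2.3-fold lower number from compound 3 to compound 4 (0.37 log units; beyond the scatter), a modest step and the first that can be read in this set. It shows that this place accepts a change in what the aromatic ring carries: bromine and a hydrogen-bond donor enter, the ring itself stays, and inhibition grows stronger rather than being lost. Nothing measured here bears on why the number falls.

Bromine and the hydroxyl enter together in this one swap, so their separate shares in the step remain open. Also open, on these data alone, is how the number would move with a chlorine atom in place of the bromine, or with an amine in place of the hydroxyl.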